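Trimethoxyphenyl in place of methoxyphenyl on the core

The compounds below may be only part of what the source reports. "The series", "measured", "known", "first", "only" and "open" are said of these compounds alone.

Measured compounds:
compound 1, `COc1cc(/C=C/C(=O)c2cccc(-n3cc(-c4ccc(Cl)cc4)[nH]c3=O)c2)cc(OC)c1OC`, in a functional assay on SNB-19 cells (Homo sapiens) for inhibition (a lower number here means a stronger inhibitor of growth, a higher number a weaker inhibitor of growth), compound 1 gives 16100 nM.
compound 2, `COc1ccc(-c2cn(-c3cccc(C(=O)/C=C/c4cc(OC)c(OC)c(OC)c4)c3)c(=O)[nH]2)cc1`, in this assay compound 2 gives 4380 nM.

Among the compounds with values here, compound 2 has the lowest of the two numbers; its nearest neighbour is compound 1, and the only measured step, a 3.7-fold lower number from compound 1 to compound 2 (0.57 log units; beyond the scatter), lies beyond the scatter. Compound 3, `COc1cc(/C=C/C(=O)c2cccc(-n3cc(-c4cc(OC)c(OC)c(OC)c4)[nH]c3=O)c2)cc(OC)c1OC`, differs from compound 2 by 3,4,5-trimethoxyphenyl in place of 4-methoxyphenyl on an aromatic carbon. Within the data shown here, no measured step covers this change directly; the one measured step involves a methoxy group entering and is modest in size, so compound 3 is expected to land close to compound 2, with at most a modest step of a 1.3-fold lower number from compound 2 to compound 3 (0.10 log units; within the scatter) in either direction. In this assay compound 3 is therefore estimated at 3500 nM, within a range of 1200 nM to 11000 nM.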

Compound 3, concentration for 50% growth inhibition: 4070 nM
For compound 3 the middle estimate is 1.2-fold (0.07 log units) below the measured one; the range from low to high includes it.
By their numbers in this assay, from the lowest: compounds 3 and 2 (each within the scatter of the next); then compound 1.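

At this aromatic carbon of the five-membered ring, this assay does not separate the two methoxy-bearing aryl groups: 3,4,5-trimethoxyphenyl in place of 4-methoxyphenyl gives a 1.1-fold lower number from compound 2 to compound 3 (0.03 log units; within the scatter) and so shows that the two further methoxy groups bring no readable difference here. Set against 4-chlorophenyl, the same 3,4,5-trimethoxyphenyl group gives a 4.0-fold lower number from compound 1 to compound 3 (0.60 log units; beyond the scatter) and so places compound 3 with compound 2, both apart from compound 1 by steps beyond the scatter. Nothing at hand explains why the two methoxy-bearing groups read alike in this assay.

The compounds shown leave open whether a 4-hydroxyphenyl or a 3,4-dimethoxyphenyl group at this carbon would read like these two. They also leave open what a non-aromatic group here, such as an amine or a carboxylic acid, would do to the number.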